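Iodo for chloro at the limit of the assay

The compounds below may be only part of what the source reports. "The series", "measured", "known", "first", "only" and "open" are said of these compounds alone.

In a functional assay on A549 cells (Homo sapiens) for antiproliferative activity, read by MTT assay, with a stated time of 72 h (on this read-out higher numbers stand for weaker inhibition and lower numbers for stronger inhibition), compound 2 (`COc1cc2ncnc(Nc3cccc(Cl)c3)c2cc1OCCCN1CCNCCNCC1`) reads > 50000 nM, which is a limit and not a number. Compound 3 (`COc1cc2ncnc(Nc3cccc(I)c3)c2cc1OCCCN1CCNCCNCC1`) carries iodo in place of chloro on an aromatic carbon, meta to a large group: iodo in place of chloro on an aromatic carbon. Compound 1 (`COc1cc2ncnc(Nc3cccc(I)c3)c2cc1OCCCN1CCNCCNCCNCC1`), also a 3-iodophenyl compound, gives 14500 nM in this assay. On that value, a small change toward stronger inhibition is expected, though compound 3 may also stay at the limit. The expected change is an at least 1.7-fold lower number from compound 2 to compound 3 (0.25 log units; that floor lies within the scatter). For compound 3 the estimate is 28000 nM, with an expected range of 13000 nM to 50000 nM.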

Compound 3, half-maximal inhibitory concentration: 26200 nM
Estimate against measurement, compound 3: 1.1-fold (0.03 log units) above; low and high end bracket the measured number.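

Going from 3-chlorophenyl to 3-iodophenyl in this assay gives an at least 1.9-fold lower number from compound 2 to compound 3 (0.28 log units; that floor lies within the scatter) and brings the series onto a readable value at this position. Replacing the larger ring with the nine-membered ring gives a 1.8-fold higher number from compound 1 to compound 3 (0.26 log units; within the scatter) and so does not separate the two rings in the 3-iodophenyl compounds. Compound 2 gives only a limit, so the full size of the halogen step stays unknown: the limit of > 50000 nM in this assay, at which 1 of the 3 values shown sits.

Where 3-bromophenyl or unsubstituted phenyl would fall remains open. Also open, going by these compounds, is how a 3-chlorophenyl compound with the larger ring would read.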